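Aminophenyl for hydroxyphenyl on the enone ketone

This account rests on a few compounds, and the source may have more. Where it says the series, first, only, none or still open, it means among the compounds named here.

Measured compounds:
compound 1 `COc1ccc(-c2cc3ccccc3nc2/C=C/C(=O)c2ccc(O)cc2)cc1`: 6930 nM
compound 2 `COc1ccc(-c2cc3ccccc3nc2/C=C/C(=O)c2ccc(OC)cc2OC)cc1`: 7040 nM
compound 3 `COc1ccc(-c2cc3ccccc3nc2/C=C/C(=O)c2ccc(OC)c(OC)c2)cc1`: 7540 nM

In a functional assay on NCI-H460 cells (Homo sapiens) for antiproliferative activity, read by XTT assay, with a stated time of 72 h (a higher number here means a weaker inhibitor, a lower number a stronger inhibitor), compound 1 gives 6930 nM, the smaller of the three numbers on paper, but a 1.0-fold higher number from compound 1 to compound 2 (0.01 log units; within the scatter) and a 1.1-fold higher number from compound 1 to compound 3 (0.04 log units; within the scatter) are both within the scatter, so the three compounds are not separated by this assay. a 1.1-fold higher number from compound 2 to compound 3 (0.03 log units; within the scatter) likewise. All three share the same core and differ only in the substitution of the ring attached to the carbonyl carbon.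

Compound 4 `COc1ccc(-c2cc3ccccc3nc2/C=C/C(=O)c2ccc(N)cc2)cc1` is not yet measured in this assay. It differs from compound 1 as follows: amino in place of hydroxy on an aromatic carbon. Going by the values given here, no measured step exchanges hydroxy for amino, so nothing bears on it directly. What the measured steps do show is that reworking the oxygen substitution on that same ring, from compound 1 to compound 2 and from compound 1 to compound 3, left the number where it was. On that basis the step from compound 1 to compound 4 is expected to stay within the scatter as well, with a 1.1-fold lower number from compound 1 to compound 4 (0.03 log units; within the scatter) as the estimate, and no direction is claimed. Compound 4 is therefore expected to give 6500 nM in this assay, within a range of 3000 nM to 14000 nM.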

Compound 4, half-maximal inhibitory concentration: 7400 nM
Compound 4: the middle estimate sits 1.1-fold (0.06 log units) below what was measured; the range from low to high includes it.
By their numbers in this assay, from the lowest: compounds 1, 2, 4 and 3 (each within the scatter of the next).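

In this assay, amino in place of hydroxy, para to a large group, gives a 1.1-fold higher number from compound 1 to compound 4 (0.03 log units; within the scatter) and so extends the flat reading at this position from oxygen substituents to a nitrogen substituent. The 4-aminophenyl ring is also not separated from the two dimethoxyphenyl rings, with a 1.1-fold higher number from compound 2 to compound 4 (0.02 log units; within the scatter) and a 1.0-fold lower number from compound 3 to compound 4 (0.01 log units; within the scatter), so in this assay the ring on the carbonyl carbon has now been varied four ways, one of them with no oxygen on that ring, without any step leaving the scatter. No measured information is available to account for this flat reading.

Going by these compounds, whether a carboxylic acid, a dimethylamino group or a longer chain such as butoxy on this ring would move the number away from this narrow band stays open. The compounds shown also keep the shared core and the enone unchanged, so what a change there would do, for example an amine in place of the methoxy group on the other aromatic ring, cannot be told from them.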